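Chloro to hydroxy at the amide chain: working notes

A few compounds are considered here, and "the series" means these few. Any claim that something is new, unique, unknown or untested is made for them only; others in the source may bear on it.

Among the compounds with values here, compound 1 `COc1ccc(CN(C(=O)CCl)c2cc(OC)c(OC)c(OC)c2)cc1O` gives 250 nM in a functional assay on HCT-116 cells (Homo sapiens) for inhibition, read by MTT assay, with a stated time of 48 h (on this read-out lower numbers stand for stronger inhibition and higher numbers for weaker inhibition), the lowest number among the three compounds measured so far. The nearest to it is compound 3 `C/C=C/C(=O)N(Cc1ccc(OC)c([N+](=O)[O-])c1)c1cc(OC)c(OC)c(OC)c1`, which in this assay gives 670 nM, a gap beyond the scatter. Compound 2 `COc1cc(NCc2cccc(O)c2)cc(OC)c1OC`, which carries no acyl group on the nitrogen, gives 67700 nM in this assay, far beyond the scatter from compound 1.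

Compound 4 `COc1ccc(CN(C(=O)CO)c2cc(OC)c(OC)c(OC)c2)cc1O` has not yet been measured. It differs from compound 1 in one place: hydroxy in place of chloro on a saturated chain carbon bound to a carbonyl carbon. Within the data shown here, no measured pair in the set shows this change, so its effect cannot be read from a recorded step. What the data do show is that the two measured amides, compound 1 and compound 3, stand far below compound 2, which lacks the acyl group.

The expectation for the step from compound 1 to compound 4 in this assay is a clear rise in the number, well beyond the scatter: a 20-fold higher number from compound 1 to compound 4 (1.30 log units; beyond the scatter). On that basis compound 4 is estimated at 5000 nM in this assay, with a range from 1000 nM to 30000 nM. Among the measured compounds shown here, the range is wide, since no comparable step is on record.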

Compound 4, half-maximal inhibitory concentration: 520 nM
For compound 4 the middle estimate is 9.6-fold (0.98 log units) above the measured one, outside the stated range (below it).
By their numbers in this assay, from the lowest: compound 1; then compounds 4 and 3 (each within the scatter of the next); then compound 2.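

In this assay, within the data shown here, hydroxy in place of chloro on a saturated chain carbon bound to a carbonyl carbon gives a 2.1-fold higher number from compound 1 to compound 4 (0.32 log units; beyond the scatter) as the first recorded step at this position, and a modest one. Chloro is therefore not needed for a number of this order in this series: with hydroxy on that carbon, which brings one hydrogen-bond donor and one hydrogen-bond acceptor where chloro counts none, compound 4 gives 520 nM and gives up only part of what compound 1 shows. Nothing on record bears on why the step is no larger than this.

As far as these compounds go, whether the same carbon accepts other groups with a similarly modest step remains open, for example an amine, a methoxy group, a carboxylic acid, or a longer chain ending in hydroxy. Among these compounds, also open is whether the exchange of chloro for hydroxy would give a step of this size with other substituents on the benzyl ring, since the only pair on record carries the hydroxy and methoxy pattern shared by compound 1 and compound 4.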